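This account rests on a few compounds, and the source may have more. Where it says the series, first, only, none or still open, it means among the compounds named here.

Compound 1 `CCCCCCCCO[C@@H]1O[C@@H](C)[C@H](OC(=O)CCCCC)[C@@H](O[C@@H]2O[C@@H](C)[C@H](OC(C)=O)[C@@H](O[C@@H]3O[C@@H](C)[C@H](OC(C)=O)[C@@H](OC(C)=O)[C@H]3O)[C@H]2OC(C)=O)[C@H]1O` carries three sugar units with an octyl chain, a hexanoyl ester and four acetyl groups. In a functional assay on KB cells (Homo sapiens) for antiproliferative activity, read by MTT assay, with a stated time of 48 h (a higher number here means that more compound is needed for the effect, a lower number that less compound is needed), compound 1 gives 17 uM, the lowest of the two numbers in hand; the nearest is compound 3 `CCCCCCCCO[C@@H]1O[C@@H](C)[C@H](OC(=O)CCCCC)[C@@H](O[C@@H]2O[C@@H](C)[C@H](OC(C)=O)[C@@H](OC(C)=O)[C@H]2OC(C)=O)[C@H]1O`, which in this assay gives 20 uM, a gap within the scatter. Compound 2 `CCCCCCCCO[C@@H]1O[C@@H](C)[C@H](OC(=O)CCCCC)[C@@H](O[C@@H]2O[C@@H](C)[C@H](OC(C)=O)[C@@H](O)[C@H]2OC(C)=O)[C@H]1O` in this assay gives only a limit, > 20 uM. Within the data shown here, the one step measured in a single place, a number no higher from compound 2 to compound 3 (the limit leaves the size open), is acetyl in place of hydrogen on an oxygen on a saturated carbon; its size is not readable because of the limit of > 20 uM in this assay, at which 1 of the 3 values shown sits.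

Compound 4 `CCCCCCCCO[C@@H]1O[C@@H](C)[C@H](OC(=O)CCCCC)[C@@H](O[C@@H]2O[C@@H](C)[C@H](OC(C)=O)[C@@H](O[C@@H]3O[C@@H](C)[C@H](OC(C)=O)[C@@H](O)[C@H]3O)[C@H]2OC(C)=O)[C@H]1O` differs from compound 1 as hydrogen in place of acetyl on an oxygen on a saturated carbon. This is the reverse of the measured step, on the third sugar rather than the second, and that step gives no usable size, so no step beyond the scatter can be expected in this assay in either direction, with the remaining risk that only a limit is returned. Compound 4 is therefore expected to give about 22 uM in this assay, in the range 12 uM to 40 uM, a step of a 1.3-fold higher number from compound 1 to compound 4 (0.11 log units; within the scatter).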

Compound 4, concentration for half-maximal effect: 19 uM
Beside the measured number, compound 4's estimate is 1.2-fold (0.06 log units) above it; measured number inside the range.
By their numbers in this assay, from the lowest: compounds 1, 4 and 3 (each within the scatter of the next).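

Acetoxy to hydroxy at this position now has a readable size in this assay: a 1.1-fold higher number from compound 1 to compound 4 (0.05 log units; within the scatter). The acetyl on this oxygen can therefore be replaced by hydrogen without a step beyond the scatter, which the pair compound 2 and compound 3 could not show, since their step cannot be read. Whether the change reads alike on both cores stays undecided: the same change on two cores in this assay, a number no higher (the limit leaves the size open) from compound 2 to compound 3 and a 1.1-fold lower number (0.05 log units; within the scatter) from compound 4 to compound 1; the limit leaves it open whether they differ

Still open, from the compounds shown here alone, is whether a different group on this oxygen, such as a longer acyl chain or an amine in place of the hydroxy, would give a step beyond the scatter in this assay. Compound 2 gives only a limit, > 20 uM.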